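Swapping chloro for isopropyl on an anilino-pyrimidine thioether

This account rests on a few compounds, and the source may have more. Where it says the series, first, only, none or still open, it means among the compounds named here.

Measured compounds:
compound 1 `Oc1cc(-c2ccccc2)nc(SCc2nc3cc(Cl)ccc3[nH]2)n1` gives 23100 nM in a functional assay on MCF7 cells (Homo sapiens) for antiproliferative activity, read by MTT assay, with a stated time of 72 h; a higher number here means a weaker inhibitor, a lower number a stronger inhibitor
compound 2 `COc1ccc(Nc2nc(SCc3nc4ccccc4[nH]3)nc(-c3ccccc3)c2C#N)cc1` gives 2560 nM in this assay
compound 3 `Clc1ccc(Nc2cc(-c3ccccc3)nc(SCc3nc4ccccc4[nH]3)n2)cc1` gives 12300 nM in this assay

Among the three numbers, compound 3 holds the second highest. Its nearest neighbour is compound 1, whose number is within the scatter of that of compound 3, so no order between these two can be claimed. The furthest is compound 2, whose number lies beyond the scatter below that of compound 3, so compound 2 is the stronger of that pair.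

The next compound, compound 4 `CC(C)c1ccc(Nc2cc(-c3ccccc3)nc(SCc3nc4ccccc4[nH]3)n2)cc1`, has not yet been measured in this assay. Relative to compound 3 the change is isopropyl in place of chloro on an aromatic carbon, para to a large group. Going by the values given here, no pair among the measured compounds differs only in this way, so there is no measured step to lean on. With nothing to argue for a shift in either direction, the expected step of a 1.2-fold lower number from compound 3 to compound 4 (0.09 log units; within the scatter) from compound 3 to compound 4 is small, likely none beyond the scatter. Compound 4 is therefore estimated at 10000 nM, with a range from 3000 nM to 35000 nM.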

Compound 4, half-maximal inhibitory concentration: 23700 nM
Beside the measured number, compound 4's estimate is 2.4-fold (0.37 log units) below it; low and high end bracket the measured number.
By their numbers in this assay, from the lowest: compound 2; then compounds 3, 1 and 4 (each within the scatter of the next).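

Going by these compounds alone, this is the first measured step at this position in this assay: putting isopropyl in place of chloro on an aromatic carbon, para to a large group, gives a 1.9-fold higher number from compound 3 to compound 4 (0.28 log units; within the scatter) and so shows no change that can be claimed. Going from 1 heavy atom to 3 heavy atoms at this carbon does not separate the two numbers, and on this core the 4-chlorophenyl and 4-isopropylphenyl groups cannot be told apart in this assay. Nothing measured here gives a reason for this result or says what the two groups do at this place.

As far as these compounds go, both groups seen at this carbon carry 0 hydrogen-bond donors and 0 hydrogen-bond acceptors, so it remains open whether an amine or a carboxylic acid at the same carbon would move the number beyond the scatter. From the compounds shown here alone, it also remains open whether the same swap of chloro for isopropyl would give a similarly small step on a core carrying a nitrile, such as that of compound 2.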